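Swapping Chloro for Trifluoromethoxy: Oral Exposure in Dogs

This account rests on a few compounds, and the source may have more. Where it says the series, first, only, none or still open, it means among the compounds named here.

Of the compounds shown here, two sharing a common core have been measured in an in vivo ADME assay on the whole organism (strain beagle) for pharmacokinetics, with Canis familiaris (Canis lupus familiaris) as the target, at a dose of 0.5 mg/kg by the oral route; on this read-out lower numbers stand for lower oral bioavailability and higher numbers for higher oral bioavailability. Compound 1, with the structure `O=C(O)CCNC(=O)c1ccc(CN(c2ccc(Cl)cc2)c2nc(-c3ccc(C(F)(F)F)cc3)cs2)cc1`, gives 16% in this assay, the lowest of the two numbers. Compound 2, with the structure `O=C(O)CCNC(=O)c1ccc(CN(c2ccc(C(F)(F)F)cc2)c2nc(-c3ccc(Cl)cc3)cs2)cc1`, gives 141% in this assay, a number that stands far above compound 1, well beyond the scatter of repeated measurements. For the measured compounds named here, the two differ in more than one place, so no single step connects them; only their two values can be compared.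

Compound 3, with the structure `O=C(O)CCNC(=O)c1ccc(CN(c2ccc(OC(F)(F)F)cc2)c2nc(-c3ccc(C(F)(F)F)cc3)cs2)cc1`, has not yet been measured. It departs from compound 1 by one change: trifluoromethoxy in place of chloro on an aromatic carbon. Going by the values given here, no measured pair shows this exact change, so there is no direct precedent. Given the spread seen between compound 1 and compound 2, a change in the group on the same ring is expected to move the number by a moderate amount, more likely upward, as the step of a number 19 percentage points higher from compound 1 to compound 3 (beyond the scatter) expresses. Compound 3 is therefore estimated at 35% in this assay, within a range from 10% to 90%.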

Compound 3, oral bioavailability: 55%
Compound 3: the middle estimate sits 20 percentage points below what was measured; the measured number falls inside the stated range.
By their numbers in this assay, from the lowest: compound 1; then compound 3; then compound 2.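

In this assay, for the compounds shown here, replacing chloro with trifluoromethoxy brings a number 39 percentage points higher from compound 1 to compound 3 (beyond the scatter) and gives the first reading of a single change on the shared core. Compound 1 and compound 2 differ in more than one place, so their gap could not be tied to any one site, whereas this step shows that the group on an aromatic carbon, para to a large group, can alone shift oral bioavailability well beyond the usual scatter. Nothing measured alongside these compounds explains the rise.

As far as these compounds go, the step rests on one pair at one position, so it remains open whether the rise belongs to trifluoromethoxy itself, to its oxygen, or simply to a group of five heavy atoms replacing a group of one. A methoxy group, a trifluoromethyl group or a nitrile at the same place, together with the same swap on the other aromatic ring, would help to separate these readings and show how far this single step can be generalised.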